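The source may hold more compounds than are shown below. What is called first, only, known or untested is meant among the compounds shown, and "the series" means these compounds.

Measured in a functional assay on A549 cells (Homo sapiens) for antiproliferative activity, read by sulforhodamine B assay, with a stated time of 48 h; on this read-out lower numbers stand for stronger inhibition of growth and higher numbers for weaker inhibition of growth:
- compound 1 `CNc1nc(Nc2ccc(OC)cc2)nc2ccccc12`: 16100 nM
- compound 2 `COc1ccc(N(C)c2nc(NCCCO)c3ccccc3n2)cc1`: 13000 nM

In this assay, for the measured compounds named here, compound 2, at 13000 nM, stands within the usual scatter of compound 1, at 16100 nM, so the two numbers set no order between these compounds. Both sit in the same region of the scale, and that region is all the data offer as a reference.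

The next compound to be tested is compound 3 `CNc1nc(N(C)c2ccc(OC)cc2)nc2ccccc12`. Compared with compound 2, it carries hydrogen in place of 2-hydroxyethyl on a saturated chain carbon bound to a nitrogen on an aromatic ring. Read one bond further out, the same difference turns 3-hydroxypropyl into methyl.

Going by the values given here, no pair of measured compounds differs in one place only, so no measured step guides the expectation in this assay. A modest step toward stronger inhibition of growth is expected, though a result within the scatter would be no surprise. The expected size is a 2.2-fold lower number from compound 2 to compound 3 (0.34 log units; beyond the scatter). For compound 3 the estimated value is 6000 nM, with an expected range from 1200 nM to 25000 nM.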

Compound 3, concentration for 50% growth inhibition in the A549 assay: 19900 nM
For compound 3 the middle estimate is 3.3-fold (0.52 log units) below the measured one, and the stated range covers the measured number.
By their numbers in the A549 assay, from the lowest: compounds 2, 1 and 3 (each within the scatter of the next).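

For the compounds shown here, the first single-place comparisons begin with compound 2 and compound 3: in the A549 assay compound 2 gives 13000 nM and compound 3 gives 19900 nM. In the A549 assay, exchanging 3-hydroxypropyl for methyl gives a 1.5-fold higher number from compound 2 to compound 3 (0.18 log units; within the scatter), so the two groups cannot be told apart here. The second comparison reads the same way for a different place, since methyl in place of hydrogen on a nitrogen on an aromatic ring gives, in the A549 assay, a 1.2-fold higher number from compound 1 to compound 3 (0.09 log units; within the scatter), which sets no order between those two compounds either. Nothing available explains why neither exchange separates the compounds.

All three compounds therefore remain in one region of the scale, and neither exchange has yet produced a step beyond the scatter. In a physicochemical assay for lipophilicity, read by HPLC, measured as octanol-water partition, with a stated time of 24 h (on this read-out higher numbers stand for higher lipophilicity and lower numbers for lower lipophilicity), compound 2 stands as "not determined" (no result reported) and compound 3 stands as "not determined" (no result reported), so no comparison can be read there. The compounds shown leave open whether a longer chain, a primary amine or a carboxylic acid in place of 3-hydroxypropyl would move the number in the A549 assay beyond the scatter, and whether any such step would hold on the other nitrogen on an aromatic ring.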